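The source may report more compounds than this note shows. Statements on the series, on what has been measured and on what is new or still open speak of the compounds shown alone.

Within the data shown here, compound 1, with the structure `COCCCN1CCc2c(sc(NC(=O)Nc3ccc(Cl)cc3)c2C(N)=O)C1`, is one of two compounds measured so far. Among the measured compounds shown here, in a functional assay (strain AB) with Danio rerio as the target, read by microscopy, with a stated time of 1 h (a lower number here means that less compound is needed, a higher number that more compound is needed for the effect), compound 1 gives 2400 nM, the only actual number in this small set. Compound 2, with the structure `CC1CCc2nc(NC(=O)Nc3ccc(Cl)cc3)sc2C1`, gives in this assay only a limit of the method, > 25000 nM, not a number. That is the situation described by the limit of > 25000 nM in this assay, at which 1 of the 2 values shown sits. For the measured compounds named here, no two measured compounds differ in just one place, so no measured step exists to lean on.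

Compound 3, with the structure `CC(C)(C)OC(=O)CCCCN1CCc2c(sc(NC(=O)Nc3ccc(Cl)cc3)c2C(N)=O)C1`, is not yet measured. It differs from compound 1 in this way: (tert-butoxycarbonyl)methyl in place of methoxy on a saturated chain carbon, three bonds along the chain from an amine nitrogen in a ring. Seen one bond further out, the change reads 3-methoxypropyl to 4-(tert-butoxycarbonyl)butyl.

Without any measured step involving a change of this kind, the direction is open. A modest move toward needing more compound seems the most likely outcome, and the step is expected to be a 1.5-fold higher number from compound 1 to compound 3 (0.16 log units; within the scatter), near the edge of the usual scatter. In this assay compound 3 is therefore estimated at 3500 nM, with a range from 1200 nM to 12000 nM.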

Compound 3, half-maximal effective concentration: 710 nM
Beside the measured number, compound 3's estimate is 4.9-fold (0.69 log units) above it, outside the stated range (below it).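

Until now, no measured change at this place on the chain was available, and the direction of any change was open. In this assay, putting (tert-butoxycarbonyl)methyl in place of methoxy gives a 3.4-fold lower number from compound 1 to compound 3 (0.53 log units; beyond the scatter) and so means that less compound is needed for the effect, which shows that this saturated chain carbon, three bonds along the chain from the amine nitrogen in the ring, can carry a much larger ester-bearing group without loss in this whole-animal read-out. Nothing measured here accounts for this gain, so the step stands as an observation without an explanation.

The change alters several things at once, including the chain, the end group and the number of hydrogen-bond acceptors, so a single step cannot show which of these matters. As far as these compounds go, it stays open whether a plain carboxylic acid at the end of the same chain, a simple unbranched alkyl chain of similar length, or an amine in that place would behave like the tert-butyl ester of compound 3.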